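Swapping the aryl sulfonamide in a thromboxane receptor antagonist

The source may hold more compounds than are shown below. What is called first, only, known or untested is meant among the compounds shown, and "the series" means these compounds.

Measured so far:
compound 1 `Cc1ccc(S(=O)(=O)N[C@H]2CC[C@@H](F)[C@@H]2C/C=C\CCCC(=O)O)cc1`: 260 nM
compound 2 `Cc1ccc(S(=O)(=O)N[C@H]2CC[C@@H](F)[C@@H]2CCCCOCC(=O)O)cc1`: 1800 nM

In a functional assay on a cell-free system (plasma) for inhibition of thromboxane A2 receptor (Homo sapiens), read by turbidimetry (a lower number here means a stronger inhibitor, a higher number a weaker inhibitor), compound 1 gives the lowest of the two numbers, with compound 2 the nearest at a 6.9-fold higher number from compound 1 to compound 2 (0.84 log units; beyond the scatter). Compound 3 `O=C(O)CCC/C=C\C[C@H]1[C@H](F)CC[C@@H]1NS(=O)(=O)c1ccc(Cl)c(Cl)c1` differs from compound 1 by 3,4-dichlorophenyl in place of 4-methylphenyl on a sulfonyl sulfur. Among the measured compounds shown here, the only measured step concerns the chain, not the sulfonyl aryl group, so nothing measured bears directly on this change. The step from compound 1 to compound 3 is therefore expected to stay close to the scatter, a 1.7-fold lower number from compound 1 to compound 3 (0.24 log units; within the scatter). Compound 3 is estimated at 150 nM, ranging from 40 nM to 600 nM.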

Compound 3, half-maximal inhibitory concentration: 630 nM
Compound 3: middle estimate off by 4.2-fold (0.62 log units), on the low side; measured number above the stated range.
By their numbers in this assay, from the lowest: compound 1; then compound 3; then compound 2.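

In this assay the sulfonyl aryl group proves not to be a neutral place on the core of compound 1: 3,4-dichlorophenyl in place of 4-methylphenyl on a sulfonyl sulfur gives a 2.4-fold higher number from compound 1 to compound 3 (0.38 log units; beyond the scatter), a modest step but beyond the scatter. So far, 4-methylphenyl remains the better of the two aryl groups with this chain. Nothing available accounts for the step. Still open, as far as these compounds go, is whether 4-chlorophenyl or 4-methoxyphenyl would match 4-methylphenyl, and whether the chain of compound 2 would respond to 3,4-dichlorophenyl in the same way.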